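The compounds below may be only part of what the source reports. "The series", "measured", "known", "first", "only" and "open" are said of these compounds alone.

In a functional assay on A549 cells (Homo sapiens) for inhibition, read by MTT assay, with a stated time of 48 h (on this read-out higher numbers stand for weaker inhibition and lower numbers for stronger inhibition), compound 1 `COc1ccc(-c2nc3cc(/C=C4\SC(=O)N(CC(=O)N5CCOCC5)C4=O)ccc3[nH]2)cc1OC` gives 8930 nM, compound 2 `COc1cc(-c2nc3cc(/C=C4\SC(=O)N(Cc5cccc(C)c5)C4=O)ccc3[nH]2)cc(OC)c1OC` gives 930 nM, and compound 3 `COc1cc(CN2C(=O)S/C(=C\c3ccc4[nH]c(-c5cc(OC)c(OC)c(OC)c5)nc4c3)C2=O)cc(OC)c1OC` gives 530 nM, which is the lowest of the three numbers, although its gap to compound 2 lies within the scatter and only its gap to compound 1 lies beyond it. Compound 4 `COc1ccc(-c2nc3cc(/C=C4\SC(=O)N(Cc5cc(OC)c(OC)c(OC)c5)C4=O)ccc3[nH]2)cc1OC` differs from compound 3 by hydrogen in place of methoxy on an aromatic carbon. Within the data shown here, no measured step changes this part of the molecule on its own; the only single-point step, a 1.8-fold lower number from compound 2 to compound 3 (0.24 log units; within the scatter), concerns the group on the ring nitrogen, and compound 1 differs from compound 4 in that same group. Compound 4 is therefore expected to sit close to compound 3, with an estimated step of a 1.4-fold higher number from compound 3 to compound 4 (0.15 log units; within the scatter). The value of compound 4 in this assay is estimated at 750 nM, with a range from 250 nM to 2500 nM.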

Compound 4, half-maximal inhibitory concentration: 130 nM
Compound 4: middle estimate off by 5.8-fold (0.76 log units), on the high side, outside the stated range (below it).
By their numbers in this assay, from the lowest: compound 4; then compounds 3 and 2 (each within the scatter of the next); then compound 1.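

In this assay the aryl group on the shared core now has a measured effect of its own, as hydrogen in place of methoxy gives (a 4.1-fold lower number from compound 3 to compound 4 (0.61 log units; beyond the scatter)), so this aromatic carbon matters where the earlier step could not show it. With 3,4-dimethoxyphenyl in both compounds, replacing (morpholin-4-yl)carbonyl with 3,4,5-trimethoxyphenyl gives the larger change (a 69-fold lower number from compound 1 to compound 4 (1.84 log units; beyond the scatter)). No evidence bears on the reason for either step. On these data alone, whether a hydroxy group or a fluorine atom on that aromatic carbon would give a similar number remains open. So does whether the methoxy-to-hydrogen step holds with 3-methylphenyl on the chain carbon.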